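Arylpiperazine series: pyridin-2-yl replacing 2-fluorophenyl

This account rests on a few compounds, and the source may have more. Where it says the series, first, only, none or still open, it means among the compounds named here.

Compound 3 `Cn1c(=O)cnn(CCCCN2CCN(c3ccccc3F)CC2)c1=O` gives 9.73 nM in an assay for displacement of a labelled ligand from Adrenergic receptor alpha-1 (Homo sapiens) (on this read-out lower numbers stand for stronger inhibition and higher numbers for weaker inhibition), the highest number of the three measured. Compound 2 `Cn1c(=O)cnn(CCCCN2CCN(c3ccccc3C#N)CC2)c1=O` gives 7.3 nM; the gap a 1.3-fold higher number from compound 2 to compound 3 (0.12 log units; within the scatter) lies within the scatter. Compound 1 `CSc1ccccc1N1CCN(CCCCn2ncc(=O)n(C)c2=O)CC1` gives 1.8 nM, with a 4.1-fold higher number from compound 1 to compound 2 (0.61 log units; beyond the scatter) and a 5.4-fold higher number from compound 1 to compound 3 (0.73 log units; beyond the scatter) both beyond the scatter.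

Compound 4 `Cn1c(=O)cnn(CCCCN2CCN(c3ccccn3)CC2)c1=O` differs from compound 3 by pyridin-2-yl in place of 2-fluorophenyl on an amine nitrogen in a ring. Going by the values given here, all three measured steps exchange a substituent on the phenyl ring; none exchanges the ring itself, so no measured step bears directly on this change. A modest weakening is expected, a 3.1-fold higher number from compound 3 to compound 4 (0.49 log units; beyond the scatter), carried as a wide range. Compound 4 is estimated at 30 nM in this assay, between 8 nM and 120 nM.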

Compound 4, inhibition constant: 262 nM
For compound 4 the middle estimate is 8.7-fold (0.94 log units) below the measured one; the whole stated range lies below it.
By their numbers in this assay, from the lowest: compound 1; then compounds 2 and 3 (each within the scatter of the next); then compound 4.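

In this assay, exchanging the aryl ring itself on the amine nitrogen costs far more than any substituent exchange on the phenyl ring so far, with pyridin-2-yl giving large steps from all three phenyl compounds (a 27-fold higher number from compound 3 to compound 4 (1.43 log units; beyond the scatter); a 36-fold higher number from compound 2 to compound 4 (1.55 log units; beyond the scatter); a 150-fold higher number from compound 1 to compound 4 (2.16 log units; beyond the scatter)). This position therefore tolerates the three substituted phenyl groups much better than pyridin-2-yl. Nothing available accounts for the size of this loss.

Compound 4 exchanges the ring and loses the substituent in a single step, leaving the two contributions unseparated. An unsubstituted phenyl group on the same amine nitrogen would bear on this.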